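Removing One Methyl from a Weak Benzylaniline

A few compounds are considered here, and "the series" means these few. Any claim that something is new, unique, unknown or untested is made for them only; others in the source may bear on it.

In a functional assay on KYSE-450 cells (Homo sapiens) for inhibition, read by MTT assay, with a stated time of 48 h (on this read-out lower numbers stand for stronger inhibition and higher numbers for weaker inhibition), compound 1 `COc1cc(NCc2ccccc2)cc(OC)c1OC` returns only a limit, > 80000 nM. Compound 2 `COc1cc(NCc2ccc(Cl)cc2)cc(OC)c1OC` also returns only a limit, > 80000 nM. Among the measured compounds shown here, compound 3 `COc1ccc(CNc2cc(OC)c(OC)c(OC)c2)cc1C` gives 73800 nM, the only true number in the set.

Compound 4 `COc1ccc(CNc2cc(OC)c(OC)c(OC)c2)cc1` carries hydrogen in place of methyl on an aromatic carbon of compound 3, ortho to a methoxy group: hydrogen in place of methyl on an aromatic carbon. For the measured compounds named here, the one measured single-site step, a step that the two limits leave unreadable from compound 1 to compound 2, is a different change, chloro in place of hydrogen, and it has no readable size to carry over. The data therefore give no grounds for expecting a shift beyond the scatter in this assay, and no firm direction. Compound 4 may also end at the ceiling of this read-out, (the limit of > 80000 nM in this assay, at which 2 of the 3 values shown sit).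

The expected change is a 1.0-fold higher number from compound 3 to compound 4 (0.01 log units; within the scatter). For compound 4, the estimated half-maximal inhibitory concentration is 75000 nM, with an expected range from 38000 nM to 150000 nM.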

Compound 4, half-maximal inhibitory concentration: 4890 nM
Compound 4: middle estimate off by 15-fold (1.19 log units), on the high side; measured number outside the range, below it.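

In this assay, among the compounds shown here, hydrogen in place of methyl on an aromatic carbon, ortho to a methoxy group, gives a 15-fold lower number from compound 3 to compound 4 (1.18 log units; beyond the scatter), so this single position carries a step that the earlier compounds could not show. Methoxy in place of chloro gives an at least 16-fold lower number from compound 2 to compound 4 (1.21 log units; beyond the scatter), and methoxy in place of hydrogen gives an at least 16-fold lower number from compound 1 to compound 4 (1.21 log units; beyond the scatter), so the methoxy group without the neighbouring methyl separates compound 4 from both compound 1 and compound 2. The sizes of these two steps are bounded rather than fixed, as both start from a limit and not a number: the limit of > 80000 nM in this assay, at which 2 of the 4 values shown sit.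

The compounds shown leave open whether fluoro, ethyl or hydroxyl in the place of that methyl would keep the lower number of compound 4. They also leave open whether ethoxy in place of the methoxy group of compound 4 would hold it.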